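Anilino to 2,3-difluorophenoxy on the shared fused core

This account rests on a few compounds, and the source may have more. Where it says the series, first, only, none or still open, it means among the compounds named here.

Measured compounds:
- compound 2 `O=C(NC1CC1)c1ccc(-c2cnn3c(NCC4CCOCC4)nc(NC4CCCC4)nc23)cc1`: 390 nM in a functional assay on HCT-116 cells (Homo sapiens) for antiproliferative activity; on this read-out higher numbers stand for weaker inhibition of growth and lower numbers for stronger inhibition of growth
- compound 3 `Cc1cc(-c2cnn3c(NCC4CCOCC4)nc(Nc4ccccc4)nc23)ccc1C(=O)NC1CC1`: 690 nM in this assay
- compound 1 `CN(c1nc(NCC2CCOCC2)n2ncc(-c3ccc(C(=O)NC4CC4)c(F)c3)c2n1)C1CCCCC1`: "not determined" (no result reported) in this assay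

Compound 3 holds the higher of the two numbers, but the gap to compound 2 lies within the scatter, so no order between them is claimed. Compound 4 `Cc1cc(-c2cnn3c(NCC4CCOCC4)nc(Oc4cccc(F)c4F)nc23)ccc1C(=O)NC1CC1` differs from compound 3 in one place: 2,3-difluorophenoxy in place of anilino on an aromatic carbon. Within the data shown here, no measured pair shows this change, so its size is unknown. The expected step from compound 3 to compound 4 in this assay is a 1.7-fold higher number from compound 3 to compound 4 (0.24 log units; within the scatter), a modest shift toward weaker inhibition, not clearly beyond the scatter. Compound 4 is estimated at 1200 nM, within a range of 300 nM to 5000 nM.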

Compound 4, concentration for 50% growth inhibition: 9 nM
Beside the measured number, compound 4's estimate is 130-fold (2.12 log units) above it; measured number outside the range, below it.
By their numbers in this assay, from the lowest: compound 4; then compounds 2 and 3 (each within the scatter of the next).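

At this aromatic carbon, between two ring nitrogen atoms, replacing anilino with 2,3-difluorophenoxy gives a 77-fold lower number from compound 3 to compound 4 (1.88 log units; beyond the scatter) in this assay, so growth inhibition is much stronger. Among these compounds, this shows that a single change at this position can shift the read-out far beyond the scatter, which the earlier compounds did not reveal. Nothing at hand bears on the cause of this step.

The oxygen link and the two fluorines enter together, so their shares remain unresolved. An unsubstituted phenoxy group and a 2,3-difluoroanilino group at this carbon would separate them.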